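Benzyloxy for methylsulfanyl at the para position of compound 2

This account rests on a few compounds, and the source may have more. Where it says the series, first, only, none or still open, it means among the compounds named here.

Compound 1 `S=C(Nc1ccccc1)N1N=C(c2ccccc2)CC1c1ccc2c(c1)OCCO2` gives 57600 nM in a functional assay on HCT-116 cells (Homo sapiens) for antiproliferative activity, read by MTT assay, with a stated time of 48 h; on this read-out higher numbers stand for weaker inhibition of growth and lower numbers for stronger inhibition of growth. Compound 2 `CSc1ccc(C2=NN(C(=S)Nc3ccccc3)C(c3ccc4c(c3)OCCO4)C2)cc1` gives 193000 nM in this assay and stands at the highest of the two numbers recorded so far; the step of a 3.4-fold higher number from compound 1 to compound 2 (0.53 log units; beyond the scatter) is the only one measured and lies beyond the scatter. Compound 3 `S=C(Nc1ccccc1)N1N=C(c2ccc(OCc3ccccc3)cc2)CC1c1ccc2c(c1)OCCO2` carries benzyloxy in place of methylsulfanyl on an aromatic carbon, placed para to a large group. Within the data shown here, no step on benzyloxy exists in this set. Among the measured compounds shown here, the one measured step bears only loosely: adding methylsulfanyl at that carbon, in the step of a 3.4-fold higher number from compound 1 to compound 2 (0.53 log units; beyond the scatter), raised the number, so a further exchange at the same carbon is taken as unlikely to bring the number back down by much. The expected step of a 1.3-fold lower number from compound 2 to compound 3 (0.11 log units; within the scatter) is estimated as small, with wide uncertainty. Compound 3 is expected at about 150000 nM, within 50000 nM to 450000 nM.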

Compound 3, concentration for 50% growth inhibition: 8530 nM
The estimate for compound 3 lay 18-fold (1.25 log units) above the measured number; measured number below the stated range.
By their numbers in this assay, from the lowest: compound 3; then compound 1; then compound 2.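

At this aromatic carbon, para to a large group, the substituent can move the number in either direction: in this assay, benzyloxy in place of methylsulfanyl gives a 23-fold lower number from compound 2 to compound 3 (1.35 log units; beyond the scatter), and benzyloxy in place of hydrogen gives a 6.8-fold lower number from compound 1 to compound 3 (0.83 log units; beyond the scatter). Among these compounds, the only earlier substituent at this carbon, methylsulfanyl, had raised the number relative to hydrogen, so compound 3 is the first case in which a group here lowers it, and growth inhibition is stronger than with hydrogen. Among these three compounds, the number therefore does not rise with each added substituent, and compound 3 goes against any such trend.

No measurement at hand explains this shift. From the compounds shown here alone, with only these compounds, the contributions of the added aromatic ring and the oxygen link cannot be separated, and how a methoxy group, a phenethyl chain or an amine at this carbon would read stays open.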